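A few compounds are considered here, and "the series" means these few. Any claim that something is new, unique, unknown or untested is made for them only; others in the source may bear on it.

Of the compounds shown here, three sharing one core have been measured in an ADME assay on L929 cells (Mus musculus) for cytotoxicity, read by resazurin assay, with a stated time of 72 h; a higher number here means a weaker inhibitor, a lower number a stronger inhibitor. Compound 1 (`CCc1ccc(C(=O)/C=C/c2ccc3c(c2)B(O)OC3)cc1`) gives > 10 ug/mL, which is a limit and not a number. Compound 2 (`O=C(/C=C/c1ccc2c(c1)B(O)OC2)c1ccc(C(F)(F)F)cc1`) gives > 10 ug/mL, also a limit. Compound 3 (`COc1ccc(C(=O)/C=C/c2ccc3c(c2)B(O)OC3)cc1`) gives > 10 ug/mL, again a limit, so its standing is known only in that form. The picture so far is the limit of > 10 ug/mL in this assay, at which 3 of the 3 values shown sit.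

Compound 4 (`CSc1ccc(C(=O)/C=C/c2ccc3c(c2)B(O)OC3)cc1`) keeps the core of compound 3 and has methylsulfanyl in place of methoxy on an aromatic carbon, para to a large group (methylsulfanyl in place of methoxy on an aromatic carbon). The closest evidence comes from other single-group swaps on an aromatic carbon: a step that the two limits leave unreadable from compound 1 to compound 3, a step that the two limits leave unreadable from compound 2 to compound 3 and a step that the two limits leave unreadable from compound 1 to compound 2. None of these steps has a readable size, so none supplies a size or direction to carry over. No step beyond the scatter is therefore expected in this assay. The expected result is a step that the limit leaves unreadable from compound 3 to compound 4. Compound 4 is estimated at 14 ug/mL, with an expected range of 6 ug/mL to 30 ug/mL.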

Compound 4, half-maximal inhibitory concentration: > 10 ug/mL
Compound 4: only a limit was reported; the forecaster's own chance of this, stated with the estimate: 85%; the middle value is on the limit's open side.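

In this assay compound 4 gives > 10 ug/mL, a limit and not a number. No step from compound 1, compound 2 or compound 3 to compound 4 can be read, and the picture stays the same: the limit of > 10 ug/mL in this assay, at which 4 of the 4 values shown sit.

Going by these compounds, how far past this limit each of the four compounds lies remains open.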